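Swapping an aryl group for cyclobutyl: expected cytotoxicity

The source may report more compounds than this note shows. Statements on the series, on what has been measured and on what is new or still open speak of the compounds shown alone.

Measured compounds:
compound 1, `O=c1nc(-c2ccccc2)c2ccc(-c3ccncc3)cc2[nH]1`, > 50000 nM
compound 2, `Cc1ccccc1-c1nc(=O)[nH]c2ccc(-c3cc[nH]n3)cc12`, > 50000 nM

In an ADME assay on THP-1 cells (Homo sapiens) for cytotoxicity, read by MTT assay, with a stated time of 72 h (a lower number here means that less compound is needed, a higher number that more compound is needed for the effect), compound 1 gives > 50000 nM, which is a limit of the assay and not a number. In this assay compound 2 gives > 50000 nM, again a limit rather than a number. So compound 2 stands at the limit of what the assay reports, and the limit of > 50000 nM in this assay, at which 2 of the 2 values shown sit, shows that both measured values sit there. Compound 3, `O=c1nc(C2CCC2)c2cc(-c3cc[nH]n3)ccc2[nH]1`, is not yet measured. It differs from compound 2 in one place: cyclobutyl in place of 2-methylphenyl on an aromatic carbon. Among the compounds with values here, no step between measured compounds is available to gauge the effect of such a change, so the expectation rests on the two limits alone. The step from compound 2 to compound 3 is expected to be none beyond the scatter, a step that the limit leaves unreadable from compound 2 to compound 3. Compound 3 is therefore expected to give about 60000 nM, within a range of 20000 nM to 200000 nM, most likely reported again as a limit.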

Compound 3, half-maximal effective concentration: > 50000 nM
Compound 3 ended at the assay's limit; the forecaster's own chance of this, stated with the estimate: 85%; the middle value does not contradict the limit.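

Compound 2 and compound 3 both end at a limit rather than a number in this assay, so no step can be read between them: the limit of > 50000 nM in this assay, at which 3 of the 3 values shown sit.

The compounds shown leave open whether cyclobutyl and 2-methylphenyl differ at all in their effect on these cells.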